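Swapping the Aryl Groups on a Shared Core

The compounds below may be only part of what the source reports. "The series", "measured", "known", "first", "only" and "open" are said of these compounds alone.

Measured in a functional assay on K562 cells (Homo sapiens) for inhibition, with a stated time of 72 h; on this read-out lower numbers stand for stronger inhibition and higher numbers for weaker inhibition:
- compound 1 `COc1ccccc1-c1ccc(CNc2nc(NC3CCC(N)CC3)nc3c2ncn3C2CCCC2)cc1`: 347 nM
- compound 2 `NC1CCC(Nc2nc(NCc3ccc(-c4cccc(F)c4)cc3)c3ncn(C4CCCC4)c3n2)CC1`: 290 nM
- compound 3 `NC1CCC(Nc2nc(NCc3ccc(-c4ccsc4)cc3)c3ncn(C4CCCC4)c3n2)CC1`: 150 nM

Compound 3, at 150 nM, sits at the low end of these numbers. The data show a 2.3-fold lower number from compound 1 to compound 3 (0.36 log units; beyond the scatter), and also a 1.9-fold lower number from compound 2 to compound 3 (0.29 log units; within the scatter), so it stands clear of only one of the other two.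

The next compound is compound 4 `NC1CCC(Nc2nc(NCc3ccc(-c4ccco4)nc3)c3ncn(C4CCCC4)c3n2)CC1`, with 6-(furan-2-yl)pyridin-3-yl in place of 4-(thiophen-3-yl)phenyl on a saturated chain carbon bound to a nitrogen on an aromatic ring.

For the measured compounds named here, three measured steps bear on this change: a 1.2-fold lower number from compound 1 to compound 2 (0.08 log units; within the scatter), a 2.3-fold lower number from compound 1 to compound 3 (0.36 log units; beyond the scatter) and a 1.9-fold lower number from compound 2 to compound 3 (0.29 log units; within the scatter). All were small, and each exchanged only the group on an aromatic carbon. Going by the values given here, no measured step alters the six-membered aromatic ring that carries that group, so the new change goes further than the data cover. In this assay, the expected result is a slight rise with no clear move beyond the scatter, estimated as a 1.7-fold higher number from compound 3 to compound 4 (0.22 log units; within the scatter). Compound 4 is estimated at 250 nM, within an expected range of 80 nM to 800 nM.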

Compound 4, half-maximal inhibitory concentration: 67 nM
Estimate against measurement, compound 4: 3.7-fold (0.57 log units) above; measured number below the stated range.
By their numbers in this assay, from the lowest: compound 4; then compounds 3, 2 and 1 (each within the scatter of the next, the first and the last beyond it).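

In this assay, the exchange of 4-(thiophen-3-yl)phenyl for 6-(furan-2-yl)pyridin-3-yl gives a 2.2-fold lower number from compound 3 to compound 4 (0.35 log units; beyond the scatter), the first step shown to alter the six-membered aromatic ring as well as the five-membered one. It shows that, at this place on a saturated chain carbon bound to a nitrogen on an aromatic ring, a six-membered aromatic ring with a hetero atom is compatible with a lower number than the carbon-only ring of compound 3, at least when paired with furan-2-yl. Nothing shown here accounts for this difference.

The two ring exchanges arrive together, so the compounds shown leave open which of them carries the step. As far as these compounds go, how a morpholine or a carboxylic acid in place of the furan-2-yl ring would read also remains open.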